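Fluorines on the Outer Phenyl of a Bisaryl Ether Amide

The source may report more compounds than this note shows. Statements on the series, on what has been measured and on what is new or still open speak of the compounds shown alone.

Compound 1 `Cc1ccc(-c2ccnc(C(=O)Nc3ccc(Oc4ccnc5[nH]ccc45)cc3)c2)cc1` gives > 10000 nM in a functional assay on MCF7 cells (Homo sapiens) for cytotoxicity, read by MTT assay, with a stated time of 72 h (a higher number here means a weaker inhibitor, a lower number a stronger inhibitor), which is a limit of the assay rather than a number. Compound 2 `O=C(Nc1ccc(Oc2ccnc3[nH]ccc23)cc1)c1cc(-c2ccc(C(F)(F)F)cc2)ccn1` gives > 10000 nM in this assay, again a limit. Compound 3 `O=C(Nc1ccc(Oc2ccnc3[nH]ccc23)c(F)c1)c1ccc(-c2ccccc2)cn1` gives 4390 nM in this assay.

Compound 3 thus stands as the only one of the three with a measured number; the other two sit at a limit. Going by the values given here, the single measured step, a step that the two limits leave unreadable from compound 1 to compound 2, cannot be read because both of its ends sit at the limit of > 10000 nM in this assay, at which 2 of the 3 values shown sit, so it says nothing about how a change on the outer phenyl shifts potency.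

Compound 4 `O=C(Nc1ccc(Oc2ccnc3[nH]ccc23)c(F)c1)c1ccc(-c2ccc(F)cc2F)cn1` is reached from compound 3 by the change (2,4-difluorophenyl in place of phenyl on an aromatic carbon). Among the compounds with values here, no measured step touches fluorine on that phenyl, and compound 3 itself has no measured neighbour differing only there. The expectation for compound 4 therefore rests on compound 3 alone, and the step of a 1.1-fold lower number from compound 3 to compound 4 (0.04 log units; within the scatter) is expected to stay within the usual scatter. The estimate for compound 4 in this assay is 4000 nM, with a range from 1500 nM to 12000 nM, and a real chance that only a limit is reported.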

Compound 4, half-maximal inhibitory concentration: > 10000 nM
Compound 4 gave a limit, no number; the forecaster's own chance of this, stated with the estimate: 30%; middle value at least 2.5-fold (0.39 log units) away from the limit.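

Going by these compounds alone, this is the first step that can be read: putting 2,4-difluorophenyl in place of phenyl, on an aromatic carbon two atoms from the ring nitrogen and para to a large group, gives an at least 2.2-fold higher number from compound 3 to compound 4 (0.35 log units; beyond the scatter) in this assay. The change adds two fluorines and leaves the count of hydrogen-bond donors and acceptors as it was, yet it moves the compound to the weaker side, beyond the scatter, so this position does not tolerate the added fluorines without loss of activity in these cells. Because compound 4 gives a limit and not a number, the true size of the loss remains unknown, and compound 3 is still the only compound with a measured value, the others sharing one ceiling: the limit of > 10000 nM in this assay, at which 3 of the 4 values shown sit.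

The two fluorines arrive together, so the compounds shown leave open whether one of them alone would produce the same loss, and which of the two matters more. Also open, as far as these compounds go, is how this position responds to a different kind of group on the outer phenyl, such as an amine or a carboxylic acid, and whether any such group would bring a number lower than that of compound 3.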